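Replacing an Aryl Sulfonamide with a Methyl Sulfonamide

The compounds below may be only part of what the source reports. "The series", "measured", "known", "first", "only" and "open" are said of these compounds alone.

Compound 1, `CCN(CC)c1ccc2cc(C(=O)c3ccc(N4CCN(S(=O)(=O)c5ccc(Br)cc5)CC4)cc3)oc2c1`: > 40000 nM
Compound 2, `CCN(CC)c1ccc2cc(C(=O)c3ccc(N4CCN(S(=O)(=O)c5ccc(F)cc5)CC4)cc3)oc2c1`: > 40000 nM

In a functional assay on SGC-7901 cells (Homo sapiens) for cytotoxicity, read by MTT assay, with a stated time of 48 h (a lower number here means a stronger inhibitor, a higher number a weaker inhibitor), compound 1 reaches only the limit of > 40000 nM. Compound 2 likewise gives only the limit > 40000 nM. The step that the two limits leave unreadable from compound 1 to compound 2 cannot therefore be read. Compound 3, `CCN(CC)c1ccc2cc(C(=O)c3ccc(N4CCN(S(C)(=O)=O)CC4)cc3)oc2c1`, differs from compound 2 by methyl in place of 4-fluorophenyl on a sulfonyl sulfur. No measured step bears on this change, and both shown values sit at the limit of > 40000 nM in this assay, at which 2 of the 2 values shown sit. Compound 3 is therefore expected to stay at that limit too, the expected step that the limit leaves unreadable from compound 2 to compound 3 giving no readable size. Compound 3 is estimated at 60000 nM, within 20000 nM to 200000 nM.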

Compound 3, half-maximal inhibitory concentration: > 40000 nM
Compound 3 was reported as a limit; the forecaster's own chance of this, stated with the estimate: 80%; the middle value does not contradict the limit.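

In this assay compound 3 gives > 40000 nM, a limit and not a number, so its steps from compound 1 and compound 2 cannot be read. The compounds shown leave open whether methyl, 4-fluorophenyl or 4-bromophenyl on the sulfonyl sulfur makes any difference to potency.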